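A few compounds are considered here, and "the series" means these few. Any claim that something is new, unique, unknown or untested is made for them only; others in the source may bear on it.

Compound 3 `OC[C@H]1O[C@@H](n2cnc3c(NCc4ccc(F)cc4F)ncnc32)[C@H](O)[C@@H]1O` gives the lowest of the two plain numbers in a functional assay on K562 cells (Homo sapiens) for antiproliferative activity, with a stated time of 72 h (a higher number here means a weaker inhibitor, a lower number a stronger inhibitor), at 9600 nM. Its nearest neighbour is compound 1 `OC[C@H]1O[C@@H](n2cnc3c(NCc4ccc(Cl)c(Cl)c4)ncnc32)[C@H](O)[C@@H]1O`, which in this assay gives 10800 nM; the difference a 1.1-fold lower number from compound 1 to compound 3 (0.05 log units; within the scatter) is within the scatter, so the two stand level. Compound 2 `COc1cc(CNc2ncnc3c2ncn3[C@@H]2O[C@H](CO)[C@@H](O)[C@H]2O)cc(OC)c1` gives in this assay only a limit of the assay, > 166000 nM.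

The step to compound 4 `COc1cccc(CNc2ncnc3c2ncn3[C@@H]2O[C@H](CO)[C@@H](O)[C@H]2O)c1O` is 2-hydroxy-3-methoxyphenyl in place of 2,4-difluorophenyl on a saturated chain carbon bound to a nitrogen on an aromatic ring. Going by the values given here, the steps that bear on it are the two that bring oxygen-bearing groups onto that phenyl: an at least 15-fold higher number from compound 1 to compound 2 (1.18 log units; beyond the scatter) and, in reverse, an at least 17-fold lower number from compound 2 to compound 3 (1.23 log units; beyond the scatter). Both are large, and both point the same way: the ring carrying two methoxy groups sat at the limit (the limit of > 166000 nM in this assay, at which 1 of the 3 values shown sits), while the halogenated rings of compound 1 and compound 3 gave measurable numbers. The 2-hydroxy-3-methoxyphenyl of compound 4 is not the same group as in compound 2, so the size is uncertain, but a large rise is expected, an 8.3-fold higher number from compound 3 to compound 4 (0.92 log units; beyond the scatter). Compound 4 is therefore estimated at 80000 nM, within 15000 nM to 300000 nM.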

Compound 4, half-maximal inhibitory concentration: 27900 nM
Beside the measured number, compound 4's estimate is 2.9-fold (0.46 log units) above it; the range from low to high includes it.
By their numbers in this assay, from the lowest: compounds 3 and 1 (each within the scatter of the next); then compound 4. At a limit, above all of these: compound 2.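

Oxygen-bearing groups on this phenyl do not in themselves push the number to a limit, as compound 2 alone gives a limit of the assay, > 166000 nM. In this assay, the 2-hydroxy-3-methoxyphenyl of compound 4 gives a plain number, with an at least 5.9-fold lower number from compound 2 to compound 4 (0.77 log units; beyond the scatter). Going by these compounds alone, its distance from the halogenated rings is modest, with a 2.9-fold higher number from compound 3 to compound 4 (0.46 log units; beyond the scatter) and a 2.6-fold higher number from compound 1 to compound 4 (0.41 log units; beyond the scatter), so the choice of oxygen-bearing group matters far more here than the earlier compounds could show.

The compounds shown do not separate the hydroxy from the methoxy, as no phenyl here carries just one of them. Going by these compounds, how an amine or a carboxylic acid on this phenyl would read also remains open.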